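The source may hold more compounds than are shown below. What is called first, only, known or untested is meant among the compounds shown, and "the series" means these compounds.

Compound 2 `CC1(C)Oc2ccc(C#N)cc2[C@@H](/N=C(\NC#N)Oc2ccccc2)[C@@H]1O` is the point of departure. In a functional assay (aorta) with Rattus norvegicus as the target (on this read-out lower numbers stand for stronger inhibition and higher numbers for weaker inhibition), compound 2 gives only a limit, > 100000 nM, which is a boundary of the measurement and not a number. Two other compounds in the set give numbers. Compound 1 `CC1(C)Oc2ccc(C#N)cc2[C@@H](/N=C(\NC#N)Nc2ccccc2)[C@@H]1O`, the analogue with a phenylamino group in place of the phenoxy group, gives 1400 nM; 1300 nM (2 entries) in this assay. Compound 3 `CC1(C)Oc2ccc(C#N)cc2[C@@H](n2cc(C#N)c3ccccc32)[C@@H]1O` gives 2200 nM in this assay. The not yet measured compound 4 `Cc1ccc(N/C(=N/[C@@H]2c3cc(C#N)ccc3OC(C)(C)[C@H]2O)NC#N)cc1C` differs from compound 2 by one change: (3,4-dimethylphenyl)amino in place of phenoxy on a carbon with a double bond to nitrogen. Among the compounds with values here, no measured pair differs in a single place, so the size of this step cannot be read from a measured step. Nevertheless a large step towards stronger inhibition is expected in this assay, because compound 1, which also carries an amino link at that carbon, sits far below the limit of compound 2 (the several entries of compound 1 in this assay, 1400 nM; 1300 nM (2 entries) against (the limit of > 100000 nM in this assay, at which 1 of the 3 values shown sits)). Compound 4 is expected to come out near 1500 nM, with a likely range from 500 nM to 5000 nM. The step that this estimate implies is an at least 66-fold lower number from compound 2 to compound 4 (1.82 log units; beyond the scatter).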

Compound 4, half-maximal inhibitory concentration: 5100 nM
Compound 4: middle estimate off by 3.4-fold (0.53 log units), on the low side; the measured number lies above the stated range.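

In this assay, within the data shown here, (3,4-dimethylphenyl)amino in place of phenoxy gives an at least 19-fold lower number from compound 2 to compound 4 (1.29 log units; beyond the scatter), the first step that can be read at this carbon with a double bond to nitrogen. On these data alone, the value of compound 2, > 100000 nM, is a limit and not a number, so the full size of the step stays unknown. Compound 4 also shows that an amino link at this carbon still gives a measurable number when the aromatic ring carries two methyl groups, which compound 1, with its unsubstituted ring, could not show.

The step changes the link and the ring together, so a 3,4-dimethylphenoxy group would be needed to separate the two changes. The compounds shown also leave open how a chlorine or a methoxy group on the ring, or a cyclohexylamino group in place of the aromatic amine, would behave.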